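Cytotoxicity notes on the shared core: next aryl amide

The source may hold more compounds than are shown below. What is called first, only, known or untested is meant among the compounds shown, and "the series" means these compounds.

In an ADME assay on PC-3 cells (Homo sapiens) for cytotoxicity, read by WST assay, tested at 100 uM (on this read-out lower numbers stand for less inhibition and higher numbers for more inhibition at the one concentration tested (going by the name of the read-out)), compound 1 `O=C(Nc1cccc(Oc2ccccn2)c1)C1CCCN(C(=O)c2cc(C(F)(F)F)cc(C(F)(F)F)c2)C1` gives 0%. Among the compounds with values here, compound 2 `O=C(Nc1cccc([N+](=O)[O-])c1)C1CCCN(C(=O)c2cc(C(F)(F)F)cc(C(F)(F)F)c2)C1` gives 9% in this assay; the one measured step is a number 9 percentage points higher from compound 1 to compound 2 (within the scatter). Of the two numbers shown, compound 2 has the highest, with compound 1 nearest and within the scatter. Compound 3 `O=C(Nc1ccc(Cl)nc1)C1CCCN(C(=O)c2cc(C(F)(F)F)cc(C(F)(F)F)c2)C1` differs from compound 2 thus: 6-chloropyridin-3-yl in place of 3-nitrophenyl on an amide-type nitrogen. Within the data shown here, no measured step covers this change; the only step known, a number 9 percentage points higher from compound 1 to compound 2 (within the scatter), lies within the scatter, so nothing beyond the scatter is expected in this assay. Compound 3 is expected to give 5%, between 0% and 20%. The expected step is a number 4 percentage points lower from compound 2 to compound 3 (within the scatter), within the scatter.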

Compound 3, a percentage reported as inhibition, at one concentration (the size of the read-out at that concentration, not a potency): 25%
Beside the measured number, compound 3's estimate is 20 percentage points below it, and the stated range ends below it.
By their numbers in this assay, from the lowest: compounds 1 and 2 (each within the scatter of the next); then compound 3.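

Within the data shown here, on the amide-type nitrogen, the aryl group can move the read-out in this assay: 6-chloropyridin-3-yl in place of 3-nitrophenyl gives a number 16 percentage points higher from compound 2 to compound 3 (beyond the scatter) and is the only step here beyond the scatter. This shows that the position is not silent, although the step is modest. No available evidence explains the shift.

The ring nitrogen and the chlorine enter together, so the compounds shown do not separate their contributions. As far as these compounds go, a chlorophenyl group and an unsubstituted pyridine ring on the same nitrogen remain open comparisons.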